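A few compounds are considered here, and "the series" means these few. Any claim that something is new, unique, unknown or untested is made for them only; others in the source may bear on it.

Measured so far in a functional assay on PC-3 cells (Homo sapiens) for cytotoxicity, read by sulforhodamine B assay; on this read-out lower numbers stand for stronger inhibition of growth and higher numbers for weaker inhibition of growth:
Compound 1, `COc1cccc(OC)c1OCCNCCOc1ccccc1OCc1ccc(Cl)cc1`, gives 14500 nM.
Compound 2, `COc1cccc(OC)c1OCCNCCOc1ccccc1OCc1cccc(C)c1`, gives 32300 nM.
Compound 3, `COc1cccc(OC)c1OCCNCCOc1ccccc1OCc1ccccc1[N+](=O)[O-]`, gives 34700 nM.

Compound 3 stands at the highest of the three numbers in this assay. Its nearest neighbour is compound 2, and that step lies within the scatter: a 1.1-fold higher number from compound 2 to compound 3 (0.03 log units; within the scatter). Compound 1 sits clearly apart from it: a 2.4-fold higher number from compound 1 to compound 3 (0.38 log units; beyond the scatter).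

The next compound, compound 4, `COc1cccc(OC)c1OCCNCCOc1ccccc1OCc1ccc(OC(C)C)cc1`, is reached from compound 3 by one change: 4-isopropoxyphenyl in place of 2-nitrophenyl on a saturated chain carbon bound to an oxygen on an aromatic ring. All three measured steps exchange one substituted phenyl for another at this same place. Two of them shifted the number modestly but beyond the scatter, a 2.2-fold higher number from compound 1 to compound 2 (0.35 log units; beyond the scatter) and a 2.4-fold higher number from compound 1 to compound 3 (0.38 log units; beyond the scatter), while the step between compound 2 and compound 3 did not. Among the compounds with values here, none of them involves an isopropoxy group, so there is no direct precedent for compound 4; what the data show is that such swaps move this read-out by modest amounts at most. Compound 1, carrying 4-chlorophenyl, gave the lowest number, 14500 nM, but a single example is thin ground for a direction.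

Compound 4 is therefore expected to give about 22000 nM, estimated to fall between 8000 nM and 60000 nM. This estimate corresponds to an expected step of a 1.6-fold lower number from compound 3 to compound 4 (0.20 log units; within the scatter).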

Compound 4, concentration for total growth inhibition: 17800 nM
Beside the measured number, compound 4's estimate is 1.2-fold (0.09 log units) above it; the measured number falls inside the stated range.
By their numbers in this assay, from the lowest: compounds 1, 4, 2 and 3 (each within the scatter of the next, the first and the last beyond it).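

In this assay, the 4-isopropoxyphenyl group is accepted at this place on the saturated chain carbon, and compound 4 stays within the scatter of all three earlier compounds (a 1.9-fold lower number from compound 3 to compound 4 (0.29 log units; within the scatter); a 1.8-fold lower number from compound 2 to compound 4 (0.26 log units; within the scatter); a 1.2-fold higher number from compound 1 to compound 4 (0.09 log units; within the scatter)). The earlier compounds shown here seemed to set compound 1 apart, and that one gap remains beyond the scatter (a 2.4-fold higher number from compound 1 to compound 3 (0.38 log units; beyond the scatter)), but compound 4 now fills the space between the two ends, so the series no longer falls into two separate groups. The direct exchange of isopropoxy for chloro on an aromatic carbon leaves no readable change, and nothing available offers an explanation for these small differences.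

Among the compounds shown, the substituent and its place on the ring change together, so the effect of either one alone remains open. Also open, as far as these compounds go, is whether an amine or a carboxylic acid on this phenyl ring, or a longer chain in place of the benzyl link, would move the number further than these swaps have.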